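The source may report more compounds than this note shows. Statements on the series, on what has been measured and on what is new or still open speak of the compounds shown alone.

In a functional assay on MCF7 cells (Homo sapiens) for cytotoxicity, read by MTT assay, with a stated time of 48 h (a higher number here means a weaker inhibitor, a lower number a stronger inhibitor), compound 1 (`O=C1/C(=C\c2ccccc2)S/C(=N/c2ccccc2)N1Cc1ccncc1`) gives 26400 nM, compound 2 (`COc1ccc(/C=C2/S/C(=N/c3ccccc3)N(Cc3ccncc3)C2=O)cc1`) gives 31500 nM and compound 3 (`COc1ccc(/C=C2/S/C(=N/c3ccccc3)N(Cc3ccncc3)C2=O)cc1OC`) gives 80700 nM, the highest number of the three. Compound 4 (`CCOc1cc(/C=C2/S/C(=N/c3ccccc3)N(Cc3ccncc3)C2=O)ccc1O`) carries 3-ethoxy-4-hydroxyphenyl in place of 3,4-dimethoxyphenyl on a double-bonded chain carbon bound to a double-bonded ring carbon. The closest evidence comes from the methoxy steps: a 1.2-fold higher number from compound 1 to compound 2 (0.08 log units; within the scatter), a 2.6-fold higher number from compound 2 to compound 3 (0.41 log units; beyond the scatter) and a 3.1-fold higher number from compound 1 to compound 3 (0.49 log units; beyond the scatter). None of them tests a hydroxy or ethoxy group, so the expectation is loose. A modest step to a lower number in this assay is expected, roughly undoing the step to compound 3 (a 2.6-fold higher number from compound 2 to compound 3 (0.41 log units; beyond the scatter)). The expected step is a 1.8-fold lower number from compound 3 to compound 4 (0.25 log units; within the scatter). For compound 4 the estimated value is 45000 nM, within an expected range of 17000 nM to 110000 nM.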

Compound 4, half-maximal inhibitory concentration: 20100 nM
Compound 4: the middle estimate sits 2.2-fold (0.35 log units) above what was measured; measured number inside the range.
By their numbers in this assay, from the lowest: compounds 4, 1 and 2 (each within the scatter of the next); then compound 3.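

In this assay 3-ethoxy-4-hydroxyphenyl in place of 3,4-dimethoxyphenyl on this carbon gives a 4.0-fold lower number from compound 3 to compound 4 (0.60 log units; beyond the scatter) even though both groups hold the same atoms, so the high number of compound 3 does not follow from the atom count of the group. The new group also stands level with the simpler ones, with a 1.6-fold lower number from compound 2 to compound 4 (0.20 log units; within the scatter) and a 1.3-fold lower number from compound 1 to compound 4 (0.12 log units; within the scatter) both within the scatter. Compound 4 thus goes against the rise seen from compound 2 to compound 3. The compounds shown leave open whether the hydroxy or the ethoxy carries the step, which 4-hydroxyphenyl and 3-ethoxyphenyl groups would separate. Nothing measured here accounts for the step.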